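Cyclopentylsulfanyl in Place of Cyclopropylamino: Expected Cytotoxicity

The compounds below may be only part of what the source reports. "The series", "measured", "known", "first", "only" and "open" are said of these compounds alone.

Measured compounds:
compound 1 `Nc1nc(NC2CC2)c2ncn(/C=C3/CC3(CO)CO)c2n1` gives > 20000 nM in an ADME assay on Akata cells (Homo sapiens) for cytotoxicity, with a stated time of 7 days (on this read-out higher numbers stand for lower toxicity in this test and lower numbers for higher toxicity in this test), a limit of the assay rather than a number.
compound 2 `CC(C)CNc1nc(N)nc2c1ncn2/C=C1/CC1(CO)CO` gives > 24000 nM in this assay, a limit.
compound 3 `CSc1nc(N)nc2c1ncn2/C=C1/CC1(CO)CO` gives > 20000 nM in this assay, a limit.

Compound 1 thus stands at a limit, with no number to place it against its neighbours. The whole of what is known about the three is the limit of > 20000 nM in this assay, at which 2 of the 3 values shown sit, and (the limit of > 24000 nM in this assay, at which 1 of the 3 values shown sits).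

Compound 4 `Nc1nc(SC2CCCC2)c2ncn(/C=C3/CC3(CO)CO)c2n1` differs from compound 1 by cyclopentylsulfanyl in place of cyclopropylamino on an aromatic carbon. Going by the values given here, three measured steps bear on this change. The two that alter the same aromatic carbon are a step that the two limits leave unreadable from compound 1 to compound 3 and a step that the two limits leave unreadable from compound 2 to compound 3, and the third, a step that the two limits leave unreadable from compound 1 to compound 2, changes the group on the nitrogen. Among the compounds with values here, none of them has a readable size, so there is no measured step on which to expect a direction for compound 4, whether toward higher or lower toxicity in this test or none beyond the scatter. The estimated step of a number no higher from compound 1 to compound 4 (the limit leaves the size open) is therefore expected to keep compound 4 close to where its relatives sit. Compound 4 is expected to give 20000 nM in this assay, with a range from 8000 nM to 50000 nM, and most likely only a limit will be reported.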

Compound 4, half-maximal cytotoxic concentration: > 20000 nM
Compound 4 ended at the assay's limit; the forecaster's own chance of this, stated with the estimate: 80%; the middle value lies on the limit itself.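

No new step can be read: compound 4, like compound 1, compound 2 and compound 3, stands at a limit of the assay, so its steps from those three have no readable size. The compounds shown leave open whether any of the four differs from another in this assay, and at what concentration any of them turns cytotoxic.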